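Chlorine position on the benzyl group and cytotoxic tolerance

The source may report more compounds than this note shows. Statements on the series, on what has been measured and on what is new or still open speak of the compounds shown alone.

Compound 1 `O=C1c2ccccc2N(Cc2ccc(Cl)c(Cl)c2)S(=O)(=O)N1Cc1ccccc1` and compound 2 `O=C1c2ccccc2N(Cc2ccccc2Cl)S(=O)(=O)N1Cc1ccccc1` share one core and differ only in the chlorinated benzyl on the sulfonamide nitrogen. In a functional assay on HEL cells (Homo sapiens) (a higher number here means that more compound is tolerated, a lower number that less compound is tolerated), compound 1 gives 200000 nM, and compound 2 gives 200000 nM. The step of no change at the digits printed from compound 1 to compound 2 (within the scatter) shows that exchanging the chlorine pattern on that ring left the tolerated concentration unchanged. For the measured compounds named here, compound 2 therefore stands level with compound 1 on the numbers so far.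

Compound 3 `O=C1c2ccccc2N(Cc2ccc(Cl)cc2)S(=O)(=O)N1Cc1ccccc1` is not yet measured. Relative to compound 2 it carries 4-chlorophenyl in place of 2-chlorophenyl on a saturated chain carbon bound to a sulfonamide nitrogen in a ring. Going by the values given here, the only step available, from compound 1 to compound 2, also moved a chlorine around the same ring and was flat, so no shift beyond the scatter is expected here either; the step of no change at the digits printed from compound 2 to compound 3 (within the scatter) is expected to be essentially nil. For compound 3 the value in this assay is estimated at 200000 nM, within a range of 100000 nM to 200000 nM.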

Compound 3, minimum cytotoxic concentration: > 5000 nM
Compound 3 ended at the assay's limit; the forecaster's own chance of this, stated with the estimate: 15%; the middle value lies beyond the limit too.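

In this assay compound 3 gives > 5000 nM, which is a limit of the assay and not a number. For the compounds shown here, no step from compound 1 or compound 2 to compound 3 can be read. Going by these compounds, whether 4-chlorophenyl differs in tolerated concentration from 2-chlorophenyl or 3,4-dichlorophenyl remains open.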